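Ring change on one carbonyl of a diacylhydrazine core

The source may report more compounds than this note shows. Statements on the series, on what has been measured and on what is new or still open speak of the compounds shown alone.

Of the compounds shown here, two have been measured in an assay on cells for agonist activity at ecdysone receptor (Bombyx mori), read by a luciferase reporter, with a stated time of 24 h; a lower number here means that less compound is needed, a higher number that more compound is needed for the effect. Compound 1, `CC(C)(C)N(NC(=O)c1cccc(F)c1)C(=O)c1ccccc1Cl`, gives 69.2 nM in this assay. Compound 2, `CC(C)(C)N(NC(=O)c1ccc(Cl)cc1)C(=O)c1ccccc1Cl`, gives 115 nM in this assay, the higher of the two numbers, though the step of a 1.7-fold higher number from compound 1 to compound 2 (0.22 log units; within the scatter) stays within the scatter of the method. Compound 3, `Cc1ccc(C(=O)NN(C(=O)c2ccccc2Cl)C(C)(C)C)c(C)c1`, has not yet been measured. It differs from compound 2 in a single place: 2,4-dimethylphenyl in place of 4-chlorophenyl on a carbonyl carbon. Within the data shown here, the only measured step that bears on this position is the one from the 3-fluorophenyl of compound 1 to the 4-chlorophenyl of compound 2, and that step was too small to stand out from repeat measurements. The data therefore offer no sign that exchanging one aryl group for another on this carbonyl carbon moves the number far. Compound 3 is accordingly expected to give about 140 nM in this assay, with a plausible range from 40 nM to 500 nM. The step of a 1.2-fold higher number from compound 2 to compound 3 (0.09 log units; within the scatter) is thus estimated to lie within the scatter, in either direction.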

Compound 3, half-maximal effective concentration: 162 nM
The estimate for compound 3 lay 1.2-fold (0.06 log units) below the measured number, within the range that was stated.
By their numbers in this assay, from the lowest: compounds 1, 2 and 3 (each within the scatter of the next, the first and the last beyond it).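

In this assay, replacing 4-chlorophenyl with 2,4-dimethylphenyl on this carbonyl carbon gives a 1.4-fold higher number from compound 2 to compound 3 (0.15 log units; within the scatter) and so does not stand out from repeat measurements, even though the entering group has no chlorine and two more carbon atoms in place of it. The same group also gives this position its first step beyond the scatter, modest in size, since 2,4-dimethylphenyl in place of 3-fluorophenyl gives a 2.3-fold higher number from compound 1 to compound 3 (0.37 log units; beyond the scatter) and shows that the aryl groups seen here are not all interchangeable in this assay. Nothing available accounts for either step.

On these data alone, all three compounds carry at this carbonyl carbon a carbon-only aromatic ring bearing fluorine, chlorine or methyl groups, so it remains open how this assay would respond to an amine, a carboxylic acid or a methoxy group on that ring, or to a cyclohexyl group in place of the ring. The rest of the shared core is also the same throughout, so these compounds say nothing about whether the same small steps would hold if another part of it were changed.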